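The compounds below may be only part of what the source reports. "The series", "measured", "known", "first", "only" and "open" are said of these compounds alone.

Compound 1: `COc1ccc(/C=C/C(=O)c2c(OC)cc(O)c(CC=C(C)C)c2O)cc1OC`, 27700 nM
Compound 2: `COc1cc(OC)c(OC)cc1/C=C/C(=O)c1c(OC)cc(O)c(CC=C(C)C)c1O`, a limit, > 50000 nM
Compound 3: `COc1cc(/C=C/C(=O)c2c(O)cc(O)cc2OC)cc(OC)c1`, 13300 nM

In a functional assay on HeLa cells (Homo sapiens) for inhibition, read by MTT assay, with a stated time of 72 h (a higher number here means a weaker inhibitor, a lower number a stronger inhibitor), compound 1 gives 27700 nM. Compound 2 reaches only a limit of this assay, > 50000 nM, so no number is known for it. Compound 3 gives 13300 nM in this assay, the lowest of the two numbers; compound 1 stands nearest, and the gap between them lies beyond the scatter.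

Compound 1 and compound 2 share one core, while compound 3 and the unmeasured compound 4, `COc1cc(/C=C/C(=O)c2c(O)cc(O)cc2OC)cc(OC)c1OC`, share another; how the two cores differ is not broken down here. The change between compound 1 and compound 2 is methoxy in place of hydrogen on an aromatic carbon. It gave an at least 1.8-fold higher number from compound 1 to compound 2 (0.25 log units; that floor lies within the scatter), and the value of compound 2 is a limit (the limit of > 50000 nM in this assay, at which 1 of the 3 values shown sits).

The change from compound 3 to compound 4 is methoxy in place of hydrogen on an aromatic carbon. It is the same kind of change, but around the place it differs: in compound 4 the methoxy enters ortho to two methoxy groups and para to a large group, while in compound 2 it entered ortho to a large group, meta to a methoxy group and para to a methoxy group.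

For compound 4 in this assay an expected step of a 1.9-fold higher number from compound 3 to compound 4 (0.27 log units; within the scatter) is set beside the measured one, resting on compound 1 and compound 2 and their step of an at least 1.8-fold higher number from compound 1 to compound 2 (0.25 log units; that floor lies within the scatter). Compound 4 is therefore estimated at 25000 nM, expected between 8000 nM and 80000 nM.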

Compound 4, half-maximal inhibitory concentration: 18900 nM
The estimate for compound 4 lay 1.3-fold (0.12 log units) above the measured number; the measured number falls inside the stated range.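

In this assay, methoxy in place of hydrogen on an aromatic carbon gave a 1.4-fold higher number from compound 3 to compound 4 (0.15 log units; within the scatter), a step too small to be told apart from repeated measurement on this core. Set beside the same kind of change on the other core, this step cannot be separated from the earlier one: the same change on two cores in this assay, an at least 1.8-fold higher number (0.25 log units; that floor lies within the scatter) from compound 1 to compound 2 and a 1.4-fold higher number (0.15 log units; within the scatter) from compound 3 to compound 4; the limit leaves it open whether they differ The series therefore gives no sign that the change behaves differently on the two cores, but it does not show that the change carries over with the same size either, and neither step, as printed, stands beyond the scatter.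

The compounds shown leave open how large the step on the core of compound 1 really is, and whether the place of the entering methoxy matters, as that place differs between the two pairs and no pair shows the same place on both cores. They also leave open whether an amine or a chlorine atom on this aromatic carbon, in place of the methoxy, would give a step beyond the scatter on either core.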